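The source may hold more compounds than are shown below. What is called first, only, known or untested is meant among the compounds shown, and "the series" means these compounds.

Measured in a physicochemical assay for pharmacokinetics, at pH 8; on this read-out higher numbers stand for a longer-lived compound and lower numbers for a shorter-lived compound:
Compound 1 `O=C(Sc1cccnc1C(=O)O)c1cccc(Cl)c1`: 14.8 h
Compound 2 `O=C(Sc1cccnc1C(=O)O)c1ccccc1Cl`: 75.8 h
Compound 3 `O=C(Sc1cccnc1C(=O)O)c1ccc(Cl)cc1`: 26.6 h

These three compounds share a core and each carries a chloro group. Compound 3, at 26.6 h, lies within the usual scatter of compound 1, while compound 2, at 75.8 h, stands clearly higher than compound 3. Compound 4 `COc1ccc(C(=O)Sc2cccnc2C(=O)O)cc1` has methoxy in place of chloro on an aromatic carbon, para to a large group (methoxy in place of chloro on an aromatic carbon). Among the compounds with values here, no measured pair shows this exchange, so the expectation in this assay is tentative: a modest rise, possibly not much beyond the scatter. The expected change is a 1.7-fold higher number from compound 3 to compound 4 (0.23 log units; within the scatter). For compound 4, the estimated half-life is 45 h, within an expected range of 20 h to 100 h.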

Compound 4, half-life: 182 h
Beside the measured number, compound 4's estimate is 4.0-fold (0.61 log units) below it, and the stated range ends below it.
By their numbers in this assay, from the lowest: compounds 1 and 3 (each within the scatter of the next); then compound 2; then compound 4.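

In this assay, methoxy in place of chloro on this aromatic carbon, para to a large group, gives a 6.8-fold higher number from compound 3 to compound 4 (0.84 log units; beyond the scatter), a step beyond the scatter. Within the data shown here, the earlier compounds all carried chloro, so this is the first sign that changing the group itself at this position can clearly lengthen the half-life. No measurement at hand explains this rise.

As far as these compounds go, it remains open whether an amine or a longer chain here would do the same. Whether methoxy would also raise the half-life where chloro sits in compound 1 and compound 2 is open too.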